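Aminopiperidine for piperazine on the cyanobenzyl core

The source may report more compounds than this note shows. Statements on the series, on what has been measured and on what is new or still open speak of the compounds shown alone.

Compound 2 `N#Cc1ccccc1Cn1c(N2CCNCC2)cc(=O)n2nccc12` carries a piperazin-1-yl group. In an ADME assay on isolated protein for inhibition of Dipeptidyl peptidase 9 (Homo sapiens), read by fluorescence, with a stated time of 10 min (a higher number here means a weaker inhibitor, a lower number a stronger inhibitor), compound 2 gives > 100000 nM, a limit of the assay and not a number. Compound 1 `Cc1ccc(Cn2c(N3CCC[C@@H](N)C3)cc(=O)n3nccc23)cc1` likewise returns only a limit, > 100000 nM, in this assay. Both readings sit at the limit of > 100000 nM in this assay, at which 2 of the 2 values shown sit, so no measured step exists and compound 2 stands at the limit of what is shown. Compound 3 `N#Cc1ccccc1Cn1c(N2CCC[C@@H](N)C2)cc(=O)n2nccc12` differs from compound 2 by 3-aminopiperidin-1-yl in place of piperazin-1-yl on an aromatic carbon. Compound 1 carries the same 3-aminopiperidin-1-yl group and reaches no measurable value in this assay. No step beyond the scatter is expected in either direction. Compound 3 is expected at 150000 nM, between 30000 nM and 1000000 nM. The step that the limit leaves unreadable from compound 2 to compound 3 is estimated to stay within the scatter.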

Compound 3, half-maximal inhibitory concentration: > 100000 nM
Compound 3 gave a limit, no number; the forecaster's own chance of this, stated with the estimate: 80%; the middle value is on the limit's open side.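

In this assay compound 3 gives > 100000 nM, a limit and not a number, so the steps to it from compound 1 and compound 2 cannot be read. The compounds shown leave open whether any change on this shared core gives a measurable value in this assay: the limit of > 100000 nM in this assay, at which 3 of the 3 values shown sit.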